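Amino in place of hydrogen across two cores

A few compounds are considered here, and "the series" means these few. Any claim that something is new, unique, unknown or untested is made for them only; others in the source may bear on it.

Compound 1 `CCn1cc(-c2nc3ccccc3[nH]2)c(=O)c2cc(F)c(N3CCNCC3)cc21` and compound 2 `CCn1cc(-c2nc3ccccc3[nH]2)c(=O)c2cc(F)c(N3CCNCC3)nc21` share most of their structure but not their cores; the difference between the two cores is not broken down here. In a functional assay on HepG2 cells (Homo sapiens) for cytotoxicity, read by sulforhodamine B assay, with a stated time of 48 h (a higher number here means a weaker inhibitor of growth, a lower number a stronger inhibitor of growth), compound 1 gives only a limit, > 10000 nM. Compound 2 gives 6800 nM in this assay. Compound 3 `CCn1cc(-c2nc3ccc(N)cc3[nH]2)c(=O)c2cc(F)c(N3CCNCC3)cc21` carries the change amino in place of hydrogen on an aromatic carbon on the core of compound 1. In this assay compound 3 likewise gives a limit, > 10000 nM. The step that the two limits leave unreadable from compound 1 to compound 3 cannot be read because both values sit at the limit of > 10000 nM in this assay, at which 2 of the 3 values shown sit.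

Compound 4 `CCn1cc(-c2nc3ccc(N)cc3[nH]2)c(=O)c2cc(F)c(N3CCNCC3)nc21` carries the same change, (amino in place of hydrogen on an aromatic carbon), on the core of compound 2. The measured step gives no readable size, so the expectation rests on compound 2 alone, at 6800 nM. The expected step of a 1.2-fold higher number from compound 2 to compound 4 (0.07 log units; within the scatter) is taken as small. Compound 4 is therefore estimated at 8000 nM, between 3000 nM and 20000 nM, with a fair chance that only a limit is reported.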

Compound 4, concentration for 50% growth inhibition: > 10000 nM
Compound 4: only a limit was reported; the forecaster's own chance of this, stated with the estimate: 40%; middle value at least 1.2-fold (0.09 log units) away from the limit.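

In this assay, amino in place of hydrogen on the core of compound 2 gives an at least 1.4-fold higher number from compound 2 to compound 4 (0.16 log units; that floor lies within the scatter). Compound 4 gives > 10000 nM, which is a limit and not a number, so this step has a floor but no readable size. The matching step on the core of compound 1 cannot be read, so the data neither show that the change carries from one core to the other nor show that it does not: the limit of > 10000 nM in this assay, at which 3 of the 4 values shown sit.

Open, from the compounds shown here alone, is whether a carboxylic acid or a methoxy group on that same aromatic carbon would give a number rather than a limit on the core of compound 2. Also open, going by these compounds, is whether any such group would give a number on the core of compound 1.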